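Lactam N-methylation in a cyclopentyl-substituted series

The source may hold more compounds than are shown below. What is called first, only, known or untested is meant among the compounds shown, and "the series" means these compounds.

Measured so far:
- compound 1, `O=C1CN(C2CCCC2)c2nc(Nc3ccc(N4CCCCC4)cc3)ncc2N1`: 25100 nM
- compound 2, `CC1CCN(c2ccc(Nc3ncc4c(n3)N(C3CCCC3)CC(=O)N4)cc2)CC1`: "not determined" (no result reported)
- compound 3, `CN1CCN(c2ccc(Nc3ncc4c(n3)N(C3CCCC3)CC(=O)N4)nc2)CC1`: "not determined" (no result reported)

For the measured compounds named here, compound 1 is the only entry with a number in an ADME assay on HEK293 cells (Homo sapiens) for inhibition, read by MTT assay, with a stated time of 48 h; a lower number here means a stronger inhibitor, a higher number a weaker inhibitor; compound 2 and compound 3 carry no result there, so nothing can be said of how they compare with compound 1, and no step between two measured compounds is available to calibrate a structural change. In this assay compound 1 gives 25100 nM, a weak value.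

Compound 4, `CN1C(=O)CN(C2CCCC2)c2nc(Nc3ccc(N4CCCCC4)cc3)ncc21`, is the next entry and is still to be measured. It differs from compound 1 by methyl in place of hydrogen on an amide-type nitrogen in a ring. Going by the values given here, no measured pair shows what this change does. With nothing to anchor a direction, the expectation is for a step from compound 1 to compound 4 of a 1.2-fold higher number from compound 1 to compound 4 (0.08 log units; within the scatter), which is to say none beyond the usual scatter.

Compound 4 is therefore estimated at 30000 nM in this assay, with a likely range of 10000 nM to 90000 nM.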

Compound 4, half-maximal inhibitory concentration: 25300 nM
Compound 4: the middle estimate sits 1.2-fold (0.07 log units) above what was measured; low and high end bracket the measured number.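

In this assay, for the compounds shown here, methyl in place of hydrogen on an amide-type nitrogen in a ring gives a 1.0-fold higher number from compound 1 to compound 4 (0.00 log units; within the scatter), the first step that can be read. In this one pair, the amide hydrogen of compound 1 is therefore not required for the read-out, and the position, three ring bonds from the ring nitrogen and three ring bonds from the ring atom that bears a cyclopentyl group, accepts a methyl without a difference beyond the scatter. Nothing measured alongside these compounds bears on why the step is so small.

Going by these compounds, whether that holds for a longer chain on the same nitrogen, such as ethyl or benzyl, or for a chain ending in an amine or a carboxylic acid, remains open. Also open, on these data alone, is whether the methyl step would read the same on a compound with a much lower number, since the pair sits at a weak level, with compound 1 at 25100 nM and compound 4 at 25300 nM.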